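Azo aniline series: cytotoxicity and a fluorophenyl swap

The source may hold more compounds than are shown below. What is called first, only, known or untested is meant among the compounds shown, and "the series" means these compounds.

compound 1 `FC(F)(F)c1cccc(/N=N/c2ccc(NC[C@@H]3CCCN4CCCC[C@H]34)c3c2CCCC3)c1`: 30000 nM
compound 2 `CCOC(=O)N1CCN(/N=N/c2ccccc2)CC1`: > 100000 nM

Going by the values given here, in an ADME assay on MDBK cells (Bos taurus) for cytotoxicity, read by MTT assay, with a stated time of 96 h (a higher number here means that more compound is tolerated, a lower number that less compound is tolerated), compound 1 gives 30000 nM, the only actual number measured so far. Compound 2 is reported only as a limit of the assay, > 100000 nM, which is the limit of > 100000 nM in this assay, at which 1 of the 2 values shown sits. Compound 3 `Fc1ccc(/N=N/c2ccc(NC[C@@H]3CCCN4CCCC[C@H]34)c3c2CCCC3)c(F)c1` has not yet been measured; it differs from compound 1 by 2,4-difluorophenyl in place of 3-(trifluoromethyl)phenyl on a double-bonded nitrogen. Among the compounds with values here, no measured pair shows this change, so compound 3 is expected to sit close to compound 1, with the step of a 1.2-fold higher number from compound 1 to compound 3 (0.07 log units; within the scatter) estimated to remain within the usual scatter. For compound 3 the estimate in this assay is 35000 nM, between 15000 nM and 90000 nM.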

Compound 3, half-maximal cytotoxic concentration: 11000 nM
Compound 3: the middle estimate sits 3.2-fold (0.50 log units) above what was measured, and the stated range ends above it.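

With the core of compound 1 held fixed, the group on the double-bonded nitrogen does move the read-out in this assay: 2,4-difluorophenyl in place of 3-(trifluoromethyl)phenyl gives a 2.7-fold lower number from compound 1 to compound 3 (0.44 log units; beyond the scatter) as a modest step. This is the first pair shown that isolates a change at this position. Nothing given here accounts for the step.

One pair cannot show whether other groups at this place would shift the read-out in the same direction. As far as these compounds go, an unsubstituted phenyl, a 4-fluorophenyl or a 4-methoxyphenyl on the same core remains open.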